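The compounds below may be only part of what the source reports. "The series", "measured", "known", "first", "only" and "open" are said of these compounds alone.

Measured so far:
compound 1 `COc1ccc(/C=C/C=C/C(=O)c2ccccc2O)cc1`: 1810 nM
compound 2 `O=C(/C=C/C=C/c1ccc([N+](=O)[O-])cc1)c1cc(Cl)ccc1O`: 1080 nM

In an in vitro assay on cells for inhibition of Amine oxidase [flavin-containing] B (Homo sapiens), read by Amplex Red, with a stated time of 15 min (on this read-out lower numbers stand for stronger inhibition and higher numbers for weaker inhibition), compound 2 gives the lowest of the two numbers shown; compound 1 gives 1810 nM, and the two values lie within the scatter, so neither stands apart. Compound 3 `O=C(/C=C/C=C/c1ccc([N+](=O)[O-])cc1)c1ccccc1O` is not yet measured. It differs from compound 2 by hydrogen in place of chloro on an aromatic carbon. For the measured compounds named here, no step of this kind between measured compounds is known, so its size cannot be read from the series. Only a small step is expected, in no clear direction, none beyond the scatter. Compound 3 is thus estimated at 1500 nM, between 600 nM and 4000 nM, which amounts to an expected step of a 1.4-fold higher number from compound 2 to compound 3 (0.14 log units; within the scatter).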

Compound 3, half-maximal inhibitory concentration: 160 nM
Estimate against measurement, compound 3: 9.4-fold (0.97 log units) above; the measured number lies below the stated range.
By their numbers in this assay, from the lowest: compound 3; then compounds 2 and 1 (each within the scatter of the next).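

In this assay, this aromatic carbon, para to a hydroxy group, proves sensitive to its substituent: hydrogen in place of chloro gives a 6.8-fold lower number from compound 2 to compound 3 (0.83 log units; beyond the scatter). Chloro is therefore not tolerated as a neutral swap for hydrogen here, at least with nitro on the other side of the compound. Nitro in place of methoxy gives an 11-fold lower number from compound 1 to compound 3 (1.05 log units; beyond the scatter), so that second place also carries a step beyond the scatter. Still open, on these data alone, is whether fluoro or methyl at the chloro position, or an amine in place of nitro, would keep the lower number. Nothing measured here accounts for either step.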